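A chloro group added to compound 2

The compounds below may be only part of what the source reports. "The series", "measured", "known", "first", "only" and "open" are said of these compounds alone.

In a functional assay on A549 cells (Homo sapiens) for cytotoxicity, read by MTT assay, with a stated time of 48 h (on this read-out higher numbers stand for weaker inhibition and lower numbers for stronger inhibition), compound 1 `CCn1c(/C=C2/C(=O)Nc3ccccc32)nc2ccccc21` reaches only a limit of the assay, > 50000 nM. For the measured compounds named here, compound 2 `CC(C)n1c(/C=C2/C(=O)Nc3ccccc32)nc2ccccc21` gives 35300 nM, the only actual number so far. Going by the values given here, the single measured step, an at least 1.4-fold lower number from compound 1 to compound 2 (0.15 log units; that floor lies within the scatter), lies at another place in the molecule and offers only a weak guide. Compound 3 `CC(C)n1c(/C=C2/C(=O)Nc3ccc(Cl)cc32)nc2ccccc21` differs from compound 2 through (chloro in place of hydrogen on an aromatic carbon), with chloro in place of hydrogen on an aromatic carbon. Among the compounds with values here, no measured step involves such a change, so only a small shift towards a lower number is expected, a 1.6-fold lower number from compound 2 to compound 3 (0.21 log units; within the scatter). Compound 3 is expected at 22000 nM, within an estimated range of 9000 nM to 50000 nM.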

Compound 3, half-maximal inhibitory concentration: 35200 nM
Beside the measured number, compound 3's estimate is 1.6-fold (0.20 log units) below it, within the range that was stated.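

In this assay, chloro in place of hydrogen on this aromatic carbon, meta to a fused ring and para to a fused ring, gives a 1.0-fold lower number from compound 2 to compound 3 (0.00 log units; within the scatter), so this position shows no measurable response to this one change. Compound 3 still gives a number rather than a limit, and the series stays close to the limit of the assay: the limit of > 50000 nM in this assay, at which 1 of the 3 values shown sits.

As far as these compounds go, whether an amine, a methoxy group or a carboxylic acid on this carbon would shift the number stays open. So does the effect of a longer chain on the aromatic nitrogen of compound 3.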